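Hydroxy to nitro on a compound at the assay limit

A few compounds are considered here, and "the series" means these few. Any claim that something is new, unique, unknown or untested is made for them only; others in the source may bear on it.

In an ADME assay on BJ cells (Homo sapiens) for cytotoxicity, with a stated time of 72 h (on this read-out lower numbers stand for an effect already at smaller amounts and higher numbers for an effect only at larger amounts of compound), compound 1 `CCc1ccc(-c2nc3c(c(C)nn3-c3ccccc3)c(-c3ccccc3O)c2C#N)cc1` gives > 20000 nM, which is a limit and not a number. Compound 2 `Cc1nn(-c2ccccc2)c2nc(-c3ccccc3)c(C#N)c(-c3ccccc3O)c12` gives > 23000 nM, also a limit. Going by the values given here, the one measured step, a step that the two limits leave unreadable from compound 1 to compound 2, is hydrogen in place of ethyl on an aromatic carbon and offers no size to carry over. Compound 3 `CCc1ccc(-c2nc3c(c(C)nn3-c3ccccc3)c(-c3ccccc3[N+](=O)[O-])c2C#N)cc1` has nitro in place of hydroxy on an aromatic carbon, ortho to a large group (nitro in place of hydroxy on an aromatic carbon). No size or direction beyond the scatter is therefore expected, and the estimated step is a number no higher from compound 1 to compound 3 (the limit leaves the size open). For compound 3 the estimate is 20000 nM, with an expected range of 8000 nM to 40000 nM.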

Compound 3, half-maximal effective concentration: > 20000 nM
Compound 3: a limit, no number (the forecaster's own chance of this, stated with the estimate: 75%); the middle value sits exactly at the limit.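

Compound 1 gives > 20000 nM, a limit. Going by these compounds alone, compound 3 gives > 20000 nM, also a limit, so no step between these two compounds can be read. The compounds shown leave open at what concentration any of them reaches the half-maximal effect in this assay.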